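Replacing a pyridyl arm with a hydroxyalkyl chain

The source may hold more compounds than are shown below. What is called first, only, known or untested is meant among the compounds shown, and "the series" means these compounds.

Of the compounds shown here, three have been measured in an ADME assay on J774.1 cells (Mus musculus) for cytotoxicity, with a stated time of 48 h; a lower number here means that less compound is needed, a higher number that more compound is needed for the effect. Compound 1 `C=CCN1[C@H](c2ccc([N+](=O)[O-])cc2)C(C(=O)OCC)C(=O)C(C(=O)OCC)[C@@H]1c1ccc([N+](=O)[O-])cc1` reaches only a limit of the assay, > 100 uM, and no number is known for it. Compound 2 `COC(=O)C1C(=O)C(C(=O)OC)[C@H](c2ccccn2)N(Cc2ccccn2)[C@@H]1c1ccccn1` gives 29.9 uM. Compound 3 `Clc1cccc(Cl)c1CO/N=C/C1CCN(CCCc2ccccc2)CC1`, built on a different scaffold, gives 28.4 uM. Among the two numbers shown, compound 2 and compound 3 sit within the scatter of each other, so neither can be set apart from the other, and the third value is a limit (the limit of > 100 uM in this assay, at which 1 of the 3 values shown sits).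

Compound 4 `COC(=O)C1C(=O)C(C(=O)OC)[C@H](c2ccccn2)N(CCCO)[C@@H]1c1ccccn1` has not yet been measured in this assay. It keeps the core of compound 2 and differs in one place: 2-hydroxyethyl in place of pyridin-2-yl on a saturated chain carbon bound to an amine nitrogen in a ring. Among the measured compounds shown here, no pair of measured compounds separated by a single change is available, so the size of this step is not anchored by any measured comparison.

Given that, the step from compound 2 to compound 4 is expected to be small, a 1.3-fold higher number from compound 2 to compound 4 (0.13 log units; within the scatter), with no clear direction beyond the scatter. Compound 4 is therefore estimated at 40 uM, within a range from 15 uM to 100 uM, with some chance that the assay reports only a limit, as it did for compound 1.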

Compound 4, concentration for half-maximal effect: 32 uM
Compound 4: middle estimate off by 1.3-fold (0.10 log units), on the high side; measured number inside the range.
By their numbers in this assay, from the lowest: compounds 3, 2 and 4 (each within the scatter of the next). At a limit, above all of these: compound 1.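

In this assay, among the compounds shown here, this change gives the first measured single-place step, and it lies within the scatter: a 1.1-fold higher number from compound 2 to compound 4 (0.03 log units; within the scatter). The exchange of pyridin-2-yl for 2-hydroxyethyl, on a saturated chain carbon bound to an amine nitrogen in a ring, takes away an aromatic ring and brings in a group with no ring and 1 hydrogen-bond donor, yet the two numbers cannot be told apart. For this one pair, then, the aromatic ring at this place is not needed for a number of this size, and the hydroxyl-bearing chain serves as well within the scatter, though nothing available here accounts for why the step is so small.

One step cannot show whether this place is indifferent to its substituent in general, and an amine or a carboxylic acid at the end of the chain, or a longer chain, could read differently. Also open, from the compounds shown here alone, is whether the same exchange would give an equally small step with other groups on the shared core.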